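Three limits and one open half-life

A few compounds are considered here, and "the series" means these few. Any claim that something is new, unique, unknown or untested is made for them only; others in the source may bear on it.

In an ADME assay on microsomes from liver (Rattus norvegicus) for metabolic stability (on this read-out higher numbers stand for a longer-lived compound and lower numbers for a shorter-lived compound), compound 1 `Nc1nc(NCCNc2ncc(-c3ncc[nH]3)c(-c3ccc(F)cc3F)n2)ccc1[N+](=O)[O-]` gives > 0.5 h, which is a limit of the assay and not a number. Compound 2 `Nc1nc(NCCNc2ncc(-c3ncc[nH]3)c(-c3ccc(F)cc3Br)n2)ccc1[N+](=O)[O-]` gives > 0.5 h, also a limit. Compound 3 `Nc1nc(NCCNc2ncc(-c3ncc[nH]3)c(-c3ccc(F)cc3C(F)(F)F)n2)ccc1[N+](=O)[O-]` gives > 0.5 h, again a limit. The whole picture so far is the limit of > 0.5 h in this assay, at which 3 of the 3 values shown sit.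

Compound 4 `Nc1nc(NCCNc2ncc(-c3ncc[nH]3)c(-c3ccc(Br)cc3F)n2)ccc1[N+](=O)[O-]` now takes the story one step further: 4-bromo-2-fluorophenyl in place of 4-fluoro-2-(trifluoromethyl)phenyl on an aromatic carbon. In words, 4-bromo-2-fluorophenyl stands in place of 4-fluoro-2-(trifluoromethyl)phenyl on an aromatic carbon.

Three measured steps change a group on this same phenyl: a step that the two limits leave unreadable from compound 1 to compound 2, a step that the two limits leave unreadable from compound 1 to compound 3 and a step that the two limits leave unreadable from compound 2 to compound 3. None of them has a readable size, so they point in no direction, and no step beyond the usual scatter can be expected from them. The expected outcome is a step that the limit leaves unreadable from compound 3 to compound 4, with no direction foreseen. For compound 4 the estimate is 0.7 h, with an expected range from 0.4 h to 1.5 h.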

Compound 4, half-life: > 0.5 h
Compound 4: a limit, no number (the forecaster's own chance of this, stated with the estimate: 85%); the middle value does not contradict the limit.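

In this assay compound 4 gives > 0.5 h, again a limit and not a number. For the compounds shown here, no step from compound 1, compound 2 or compound 3 to compound 4 can be read. The true half-lives of all four compounds, and whether these phenyl changes alter them, stay open: the limit of > 0.5 h in this assay, at which 4 of the 4 values shown sit.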